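The source may hold more compounds than are shown below. What is called first, only, known or untested is meant among the compounds shown, and "the series" means these compounds.

Measured so far in an assay on isolated protein for inhibition of Indoleamine 2,3-dioxygenase 1 (Homo sapiens), read by spectrophotometry, with a stated time of 1 h; a lower number here means a stronger inhibitor, a higher number a weaker inhibitor:
compound 1 `O=[N+]([O-])c1ccc(N/C(=N\O)c2ccccc2F)c2nonc12` gives 63 nM
compound 2 `O=[N+]([O-])c1ccc(N/C(=N\O)c2cccc(F)c2)c2nonc12` gives 75 nM
compound 3 `O=[N+]([O-])c1ccc(N/C(=N\O)c2cccc(Br)c2)c2nonc12` gives 105 nM

Compound 3 carries the highest of the three numbers, but the steps of a 1.7-fold higher number from compound 1 to compound 3 (0.22 log units; within the scatter) and a 1.4-fold higher number from compound 2 to compound 3 (0.15 log units; within the scatter) both lie within the scatter, so on these numbers compound 3 cannot be set apart from compound 1 or compound 2 in this assay.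

Compound 4 `O=[N+]([O-])c1ccc(N/C(=N\O)c2ccc(Br)cc2)c2nonc12` differs from compound 3 by 4-bromophenyl in place of 3-bromophenyl on a carbon with a double bond to nitrogen. For the measured compounds named here, two measured steps bear on this. The move of a fluoro substituent from one place on the ring to another, a 1.2-fold higher number from compound 1 to compound 2 (0.08 log units; within the scatter), stayed within the scatter, and the exchange of the halogen at the same place, a 1.4-fold higher number from compound 2 to compound 3 (0.15 log units; within the scatter), also stayed within the scatter. Going by the values given here, no measured pair sets a 4-substituted phenyl against a 3-substituted one, so the direction is open, but the series gives no ground to expect a step beyond the scatter in this assay. For compound 4 the expected step is a 1.1-fold higher number from compound 3 to compound 4 (0.06 log units; within the scatter). Compound 4 is therefore estimated at 120 nM, with a range from 50 nM to 300 nM.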

Compound 4, half-maximal inhibitory concentration: 117 nM
For compound 4 the middle estimate is 1.0-fold (0.01 log units) above the measured one, within the range that was stated.
By their numbers in this assay, from the lowest: compounds 1, 2, 3 and 4 (each within the scatter of the next).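

Set against 3-bromophenyl, 4-bromophenyl on the carbon with a double bond to nitrogen gives the first measured comparison of these two placements of one halogen in this assay (a 1.1-fold higher number from compound 3 to compound 4 (0.05 log units; within the scatter)), and the step lies within the scatter. The steps to the fluoro compounds (a 1.6-fold higher number from compound 2 to compound 4 (0.19 log units; within the scatter); a 1.9-fold higher number from compound 1 to compound 4 (0.27 log units; within the scatter)) also lie within the scatter, so 4-bromophenyl cannot be set apart from any of the other three phenyl groups at this place. Nothing available accounts for how close these numbers lie.

Going by these compounds, the phenyl ring in these compounds carries only fluoro or bromo, so it remains open whether an amine, a carboxylic acid or a methoxy group there would stay within the scatter. On these data alone, whether chloro or iodo would do the same also remains open.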